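A Chain Lengthened at the Limit of the Assay

A few compounds are considered here, and "the series" means these few. Any claim that something is new, unique, unknown or untested is made for them only; others in the source may bear on it.

- Compound 1 `CCn1ccnc1-c1cc(OC)c(OC)c(OC)c1`: > 100000 nM
- Compound 2 `CCCn1ccnc1-c1cc(OC)c(OC)c(OC)c1`: > 100000 nM
- Compound 3 `CCCCn1ccnc1-c1cc(OC)c(OC)c(OC)c1`: > 100000 nM

In a functional assay on T47D cells (Homo sapiens) for antiproliferative activity, read by MTT assay, with a stated time of 72 h (on this read-out lower numbers stand for stronger inhibition and higher numbers for weaker inhibition), compound 3 gives > 100000 nM, which is a limit and not a number. Among the measured compounds shown here, it has company there, for the series so far consists of the limit of > 100000 nM in this assay, at which 3 of the 3 values shown sit. For the measured compounds named here, no measured compound therefore offers a number to count from.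

Compound 4 `CCCCCn1ccnc1-c1cc(OC)c(OC)c(OC)c1` is the next member, and the change is methyl in place of hydrogen on a saturated chain carbon, four bonds along the chain from an aromatic nitrogen. In words, this is methyl in place of hydrogen on a saturated chain carbon, four bonds along the chain from an aromatic nitrogen.

The measured steps that bear on it lengthen the same chain. There is a step that the two limits leave unreadable from compound 1 to compound 2, then a step that the two limits leave unreadable from compound 2 to compound 3, and taken together a step that the two limits leave unreadable from compound 1 to compound 3. Going by the values given here, none of them has a size that can be read, so they set no scale for this change, and they show no compound leaving the limit. In this assay no step beyond the scatter is therefore expected, and no direction can be given with confidence. The expected change is a number no higher from compound 3 to compound 4 (the limit leaves the size open). Compound 4 will most likely be reported as a limit again. For compound 4 the estimated value is 100000 nM, with an expected range from 40000 nM to 200000 nM.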

Compound 4, half-maximal inhibitory concentration: 64400 nM
Estimate against measurement, compound 4: 1.6-fold (0.19 log units) above; low and high end bracket the measured number.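

In this assay, among the compounds shown here, compound 4 is the one member of the series that gives a number, 64400 nM, so this place, four bonds along the chain from an aromatic nitrogen, is the first where a step can be read. Going by these compounds, the same compound yields three floors: the methyl at this place gives an at least 1.5-fold lower number from compound 3 to compound 4 (0.19 log units; that floor lies within the scatter), the ethyl three bonds along the chain gives an at least 1.5-fold lower number from compound 2 to compound 4 (0.19 log units; that floor lies within the scatter), and the propyl two bonds along the chain gives an at least 1.5-fold lower number from compound 1 to compound 4 (0.19 log units; that floor lies within the scatter), each floor lying within the scatter, so that the real size of these steps stays unknown. The steps among compound 1, compound 2 and compound 3 cannot be read, as those three compounds stay at a limit and not a number: the limit of > 100000 nM in this assay, at which 3 of the 4 values shown sit.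

The compounds shown leave open whether a longer chain would bring the number lower still or would leave it where compound 4 stands. They also leave open what an amine or a carboxylic acid in place of this methyl would give.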